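Swapping a Basic Amine Chain for an Ether on the Sulfonamide Aryl

This account rests on a few compounds, and the source may have more. Where it says the series, first, only, none or still open, it means among the compounds named here.

Compound 1 `CC1(C)CCC(CN2CCN(c3ccc(C(=O)NS(=O)(=O)c4ccc(NCC5CCOCC5)c([N+](=O)[O-])c4)c(Oc4cnc5[nH]ccc5c4)c3)CC2)=C(c2ccccc2C(F)(F)F)C1`: 1.7 nM
Compound 2 `CCN(CC)CCCNc1ccc(S(=O)(=O)NC(=O)c2ccc(N3CCN(CC4=C(c5ccc(C(F)(F)F)cc5)CC(C)(C)CC4)CC3)cc2Oc2cnc3[nH]ccc3c2)cc1[N+](=O)[O-]`: 0.3 nM

In an assay on isolated protein for displacement of a labelled ligand from Apoptosis regulator Bcl-2 (Homo sapiens), with a stated time of 15 min (a higher number here means a weaker inhibitor, a lower number a stronger inhibitor), compound 2 gives the lower of the two numbers, and compound 1 sits beyond the scatter above it. Compound 3 `CC1(C)CCC(CN2CCN(c3ccc(C(=O)NS(=O)(=O)c4ccc(OCC5CCOC5)c([N+](=O)[O-])c4)c(Oc4cnc5[nH]ccc5c4)c3)CC2)=C(c2ccc(C(F)(F)F)cc2)C1` carries (oxolan-3-yl)methoxy in place of (3-(diethylamino)propyl)amino on an aromatic carbon. Within the data shown here, no measured pair isolates this change, so the size of its step is open. The nearest reference is compound 1, whose value of 1.7 nM comes with a cyclic ether chain in this position, though with a different trifluoromethyl placement. A moderate weakening is expected, with a 5.0-fold higher number from compound 2 to compound 3 (0.70 log units; beyond the scatter). Compound 3 is estimated at 1.5 nM, between 0.5 nM and 5 nM.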

Compound 3, half-maximal inhibitory concentration: 4.4 nM
Beside the measured number, compound 3's estimate is 2.9-fold (0.47 log units) below it; the measured number falls inside the stated range.
By their numbers in this assay, from the lowest: compound 2; then compound 1; then compound 3.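

In this assay, (oxolan-3-yl)methoxy in place of (3-(diethylamino)propyl)amino, on the aromatic carbon ortho to a nitro group, gives a 15-fold higher number from compound 2 to compound 3 (1.17 log units; beyond the scatter), so the number at this position depends strongly on the group it carries. Among these compounds, the change swaps the linking nitrogen for oxygen, removes the hydrogen-bond donor and replaces the open chain with a ring, all at once, and the single step cannot separate these. No evidence here explains the step. Going by these compounds, it remains open whether a (3-(diethylamino)propoxy) chain or an (oxolan-3-yl)methylamino group would stay nearer compound 2 or compound 3.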